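This account rests on a few compounds, and the source may have more. Where it says the series, first, only, none or still open, it means among the compounds named here.

Measured compounds:
- Compound 1 `CCCCCCCCOc1nc(N)nc2c1ncn2/C=C1/CC1(CO)CO`. In an ADME assay on CCRF-HSB-2 cells (Homo sapiens) for cytotoxicity, with a stated time of 7 days (a higher number here means that more compound is tolerated, a lower number that less compound is tolerated), compound 1 gives > 20000 nM, which is a limit of the assay rather than a number.
- Compound 2 `CC(C)CNc1nc(N)nc2c1ncn2/C=C1/CC1(CO)CO`. In this assay compound 2 gives > 20000 nM, likewise a limit of the assay.
- Compound 3 `Nc1nc(SC2CCCC2)c2ncn(/C=C3/CC3(CO)CO)c2n1`. In this assay compound 3 gives 91000 nM.

Compound 2 therefore stands at the limit of > 20000 nM in this assay, at which 2 of the 3 values shown sit, so its cytotoxicity can only be said to lie beyond that point. The next compound, compound 4 `CC(C)Sc1nc(N)nc2c1ncn2/C=C1/CC1(CO)CO`, differs from compound 2 at one place: isopropylsulfanyl in place of isobutylamino on an aromatic carbon. Two measured steps start or end at compound 2 and change the same aromatic carbon: a step that the two limits leave unreadable from compound 1 to compound 2 and a step that the limit leaves unreadable from compound 2 to compound 3. A third, a step that the limit leaves unreadable from compound 1 to compound 3, is equally unreadable. Within the data shown here, none of these gives a direction or a size, so no step beyond the scatter can be expected in this assay, only that compound 4 is likely to be tolerated at high concentration as the others are. Compound 4 is expected to give about 40000 nM, in the range 20000 nM to 150000 nM. That estimate means an expected step that the limit leaves unreadable from compound 2 to compound 4, measured from a limit.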

Compound 4, half-maximal cytotoxic concentration: 94000 nM
Beside the measured number, compound 4's estimate is 2.4-fold (0.37 log units) below it, within the range that was stated.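

In this assay, isopropyl in place of cyclopentyl on a sulfur gives a 1.0-fold higher number from compound 3 to compound 4 (0.01 log units; within the scatter). Among these compounds, this is the first comparison at this aromatic carbon that rests on two real numbers rather than a limit, and it shows that the ring of compound 3 and the open branched group of compound 4 cannot be told apart here. The steps that link compound 4 to compound 1 and compound 2 cannot be read, because those two compounds stop at a limit of the assay: the limit of > 20000 nM in this assay, at which 2 of the 4 values shown sit.

On these data alone, it remains open how a longer chain such as octyl or a phenyl ring on the sulfur would read in this assay. Also open, as far as these compounds go, is whether the linking sulfur itself matters, since no readable step compares it with a linking oxygen or nitrogen.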